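Nitro in Place of Phenyl on a Shared Core

This account rests on a few compounds, and the source may have more. Where it says the series, first, only, none or still open, it means among the compounds named here.

Two compounds on a shared core have been examined in an assay on HEK293 cells for agonist activity at Toll-like receptor 8 (Homo sapiens), read by reporter gene assay; on this read-out lower numbers stand for an effect already at smaller amounts and higher numbers for an effect only at larger amounts of compound. Compound 1 `CCCCCn1c(N)nc2c(C)cccc21` carries a methyl group and gives 1130 nM in this assay. For the measured compounds named here, compound 2 `CCCCCn1c(N)nc2c(-c3ccccc3)cccc21` carries a phenyl group at the same place and gives "not active" (no number reported) in this assay, so no single number stands for compound 2 and no step between it and compound 1 can be measured. Compound 3 `CCCCCn1c(N)nc2c([N+](=O)[O-])cccc21` is the next member: it differs from compound 2 by nitro in place of phenyl on an aromatic carbon. Going by the values given here, no step between measured compounds is available to guide the direction. Since the only numbered result comes from compound 1 with 1130 nM, while compound 2 gives "not active" (no number reported), a return toward a measurable number is expected for compound 3, though whether this comes about cannot be settled from the present results. Compound 3 is expected to give 2500 nM in this assay, with a range from 500 nM to 15000 nM.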

Compound 3, half-maximal effective concentration: "not active" (no number reported)
Compound 3 has no reported number here, and the estimate cannot be compared.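

In this assay compound 2 gives "not active" (no number reported) and compound 3 gives "not active" (no number reported) so no step can be read between them. Nothing available bears on this result. The compounds shown leave open how groups other than methyl, phenyl and nitro at this place would read out.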